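A few compounds are considered here, and "the series" means these few. Any claim that something is new, unique, unknown or untested is made for them only; others in the source may bear on it.

Compound 1 `C=C(C)C(=O)N(C)C(=O)/C=C/c1cc(OC)c(OC)c(OC)c1`: 5600 nM
Compound 2 `C=C(C)C(=O)N(Cc1ccccc1C)C(=O)/C=C/c1cc(OC)c(OC)c(OC)c1`: 4200 nM

Both values come from a functional assay on DU-145 cells (Homo sapiens) for inhibition, read by WST assay, with a stated time of 48 h; a lower number here means a stronger inhibitor of growth, a higher number a weaker inhibitor of growth. Compound 2 stands level with compound 1, since the two numbers lie within the scatter of each other.

Next is compound 3 `C#CCN(C(=O)/C=C/c1cc(OC)c(OC)c(OC)c1)C(=O)C(=C)C`, with this change: ethynyl in place of 2-methylphenyl on a saturated chain carbon bound to an amide-type nitrogen. In words, ethynyl takes the place of 2-methylphenyl on a saturated chain carbon bound to an amide-type nitrogen, which also reads as 2-methylbenzyl to propargyl.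

Among the measured compounds shown here, one measured step bears on this place, where 2-methylphenyl replaced hydrogen: a 1.3-fold lower number from compound 1 to compound 2 (0.12 log units; within the scatter). For the measured compounds named here, no compound with ethynyl has been measured yet. Going by the values given here, with only that small step as a guide, no change beyond the scatter is expected in this assay, in either direction. The estimated step is a 1.1-fold higher number from compound 2 to compound 3 (0.06 log units; within the scatter). The expected value for compound 3 is 4800 nM, with an estimated range of 2200 nM to 10000 nM.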

Compound 3, concentration for 50% growth inhibition: 2300 nM
The estimate for compound 3 lay 2.1-fold (0.32 log units) above the measured number, and the stated range covers the measured number.
By their numbers in this assay, from the lowest: compounds 3, 2 and 1 (each within the scatter of the next, the first and the last beyond it).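

In this assay, among the compounds shown here, ethynyl in place of hydrogen on a saturated chain carbon bound to an amide-type nitrogen gives the first modest step at this place (a 2.4-fold lower number from compound 1 to compound 3 (0.39 log units; beyond the scatter)), whereas 2-methylphenyl at the same place stayed within the scatter. The direct exchange of 2-methylbenzyl for propargyl (a 1.8-fold lower number from compound 2 to compound 3 (0.26 log units; within the scatter)) also stays within the scatter, so compound 2 and compound 3 cannot be separated, although the six-membered aromatic ring is gone from compound 3. No measurement at hand accounts for the step.

From the compounds shown here alone, it remains open whether the triple bond matters, which a saturated propyl chain at this place would test. Also open, going by these compounds, is how an amine or a carboxylic acid on the same chain carbon would read in this assay.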